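The source may hold more compounds than are shown below. What is called first, only, known or untested is meant among the compounds shown, and "the series" means these compounds.

Measured so far:
compound 1, `CCC(Nc1nc(C)nc2c1nnn2-c1ccc(C(C)C)cc1Br)C(=O)OC`: 19.4 nM
compound 2, `CCCCN(CC)c1nc(C)nc2c1nc(C)n2-c1ccc(C(C)C)cc1Br`: 0.9 nM

Both compounds were run in an in vitro assay on 293-EBNA cells for binding affinity to corticotropin-releasing factor receptor 1 (Homo sapiens); a lower number here means a stronger inhibitor, a higher number a weaker inhibitor. Compound 1 carries the higher of the two numbers; compound 2 sits well below it, a gap that lies beyond the scatter of repeats. The two differ in several places at once, so no single step can be read from this pair, and the gap only shows that the shared core tolerates substantial change at the carbon opposite the ring nitrogen while keeping affinity.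

Compound 3, `CCOCC(COCC)Oc1nc(C)nc2c1nnn2-c1ccc(C(C)C)cc1Br`, has not yet been measured. It differs from compound 1 in one place: a group of 10 heavy atoms (7 carbon, 3 oxygen; no ring) in place of a group of 8 heavy atoms (5 carbon, 1 nitrogen, 2 oxygen; no ring), on an aromatic carbon The group that leaves is the one bearing the single hydrogen-bond donor of that position; the group that enters holds no donor and three acceptors, and is made of carbon and oxygen only.

With no measured step of this kind in the set, the direction is uncertain. The expectation is that the number moves downward from compound 1 by a 4.9-fold lower number from compound 1 to compound 3 (0.69 log units; beyond the scatter), short of the level of compound 2. For compound 3 the estimate in this assay is 4 nM, with a range from 0.9 nM to 15 nM.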

Compound 3, inhibition constant: 39.7 nM
The estimate for compound 3 lay 9.9-fold (1.00 log units) below the measured number; the measured number lies above the stated range.
By their numbers in this assay, from the lowest: compound 2; then compound 1; then compound 3.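

In this assay, the group of 10 heavy atoms (7 carbon, 3 oxygen; no ring) in place of the group of 8 heavy atoms (5 carbon, 1 nitrogen, 2 oxygen; no ring), on the aromatic carbon opposite the ring nitrogen, gives a 2.0-fold higher number from compound 1 to compound 3 (0.31 log units; beyond the scatter) and so costs only modestly, though the step lies beyond the scatter. The hydrogen-bond donor of the leaving group is therefore not needed to keep affinity at this position, since the entering group has none and the number rises only this far. Nothing in hand bears on why the number rises.

The one step changes both the atom attached to the aromatic carbon and the side chains, so the compounds shown cannot separate the two: an ether carrying the side chain of compound 1, or an amine carrying the two ethoxymethyl arms of compound 3, would do so. Also open, as far as these compounds go, is how this position responds to a carboxylic acid in place of the methyl ester of compound 1.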